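The compounds below may be only part of what the source reports. "The series", "measured", "known", "first", "only" and "open" are said of these compounds alone.

Measured compounds:
compound 1 `CC(C)c1n[nH]c2c(NCc3ccc(-c4ccccn4)cc3)nc(SCC3CNC(=O)O3)nc12`: 80 nM
compound 2 `CC(C)c1n[nH]c2c(NCc3ccc(-c4ccccn4)cc3)nc(SCC(C)(C)O)nc12`: 507 nM

In a functional assay on HT cells (Homo sapiens) for antiproliferative activity, read by fluorescence, with a stated time of 72 h (on this read-out lower numbers stand for stronger inhibition of growth and higher numbers for weaker inhibition of growth), compound 1 gives the lower of the two numbers at hand, and compound 2 stands a 6.3-fold higher number from compound 1 to compound 2 (0.80 log units; beyond the scatter). Among the measured compounds shown here, that single step is the only measured change, and it replaces a ring-bearing group on the chain by an open-chain one.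

Compound 3 `CC(C)c1n[nH]c2c(NCc3ccc(-c4ccccn4)cc3)nc(SCCNC(N)=O)nc12` has not yet been tested in this assay. It differs from compound 1 by ureidomethyl in place of 2-oxo-1,3-oxazolidin-5-yl on a saturated chain carbon bound to a sulfur. The step from compound 1 to compound 2 bears on this change only loosely: both replace the same ring on the same chain carbon with an open chain, but the group entering here keeps a carbonyl and gains a donor, whereas the group entering in compound 2 does not. A modest loss is therefore expected, smaller than the step to compound 2, but the direction is not secure. For compound 3 the expected step is a 2.8-fold higher number from compound 1 to compound 3 (0.44 log units; beyond the scatter). Compound 3 is estimated at 220 nM, with a range of 80 nM to 700 nM.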

Compound 3, concentration for 50% growth inhibition: 240 nM
Beside the measured number, compound 3's estimate is 1.1-fold (0.04 log units) below it; the range from low to high includes it.
By their numbers in this assay, from the lowest: compound 1; then compound 3; then compound 2.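

In this assay, a second open-chain group on a saturated chain carbon bound to a sulfur also gives a higher number than 2-oxo-1,3-oxazolidin-5-yl, with ureidomethyl giving a 3.0-fold higher number from compound 1 to compound 3 (0.48 log units; beyond the scatter) and leaving the ring-bearing compound 1 with the lowest number of the three; neither open-chain compound goes against this. The open-chain groups do not read alike at this place, since ureidomethyl in place of 1-hydroxy-1-methylethyl gives a 2.1-fold lower number from compound 2 to compound 3 (0.32 log units; beyond the scatter) and the size of the loss therefore depends on which group enters, not only on the ring leaving. Nothing at hand accounts for either step.

Three compounds cannot separate the ring itself from the groups it carries, and an open-chain carbamate or a five-membered lactam at this place would bear directly on that question. On these data alone, how a primary amine, a carboxylic acid or a longer chain ending in the ureido group would read on this sulfur-bound chain also remains open.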